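This account rests on a few compounds, and the source may have more. Where it says the series, first, only, none or still open, it means among the compounds named here.

In an assay on Sf9 cells for inhibition of protein deacetylase HDAC6 (Homo sapiens), read by fluorescence, with a stated time of 40 min, tested at 100 nM (a lower number here means less inhibition, a higher number more inhibition at the concentration tested (going by the name of the read-out)), three compounds have been measured so far. Compound 1 `Nc1ccccc1NC(=O)c1ccc(NCc2nc(-c3ccccc3)nn2-c2ccccc2)cc1` gives 5%. Compound 2 `O=C(NO)c1ccc(NCc2nc(-c3ccccc3)nn2-c2ccc(F)cc2)cc1` gives 67.6%, the highest of the three numbers. Compound 3 `Cc1cccc(-c2nc(CNc3ccc(C(=O)NO)cc3)n(-c3ccccc3)n2)c1` gives 64.1%, which sits within the usual scatter of compound 2, so the two cannot be told apart; compound 1 lies far below both, beyond the scatter. Compound 4 `CCc1ccc(-n2nc(-c3ccccc3)nc2CNc2ccc(C(=O)NO)cc2)cc1` has not yet been measured. It differs from compound 2 in one place: ethyl in place of fluoro on an aromatic carbon. For the measured compounds named here, no measured pair shows this change, so the expectation rests on compound 2 at 67.6%. The expected step, a number 7.6 percentage points lower from compound 2 to compound 4 (within the scatter), is a slight decrease that stays within the scatter. Compound 4 is estimated at 60%, between 40% and 78%.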

Compound 4, a percentage reported as inhibition, at one concentration (the size of the read-out at that concentration, not a potency): 38.3%
Beside the measured number, compound 4's estimate is 21.7 percentage points above it; measured number outside the range, below it.
By their numbers in this assay, from the lowest: compound 1; then compound 4; then compounds 3 and 2 (each within the scatter of the next).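

For the compounds shown here, putting ethyl in place of fluoro on this aromatic carbon gives a number 29.3 percentage points lower from compound 2 to compound 4 (beyond the scatter) and is the first change in one place that can be read in this set. It shows that the reading in this assay is sensitive to the group at this position, para to a large group, even though the swap adds little in size by heavy-atom count. Going by these compounds, whether the fall continues with a longer chain such as propyl, or reverses with methoxy or an amine here, stays open. Going by these compounds alone, nothing measured so far gives a reason for this drop.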